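The source may hold more compounds than are shown below. What is called first, only, known or untested is meant among the compounds shown, and "the series" means these compounds.

Series notes. Compound 1 `COc1cc(NC(C)CCCN2C(=O)CN(C(=O)[C@@H](C)N)C2(C)C)c2ncccc2c1`, compound 2 `COc1cc(NC(C)CCCN2C(=O)CN(C(=O)CN)C2(C)C)c2ncccc2c1` and compound 3 `COc1cc(NC(C)CCCN2C(=O)CN(C(=O)[C@H](N)C(C)C)C2(C)C)c2ncccc2c1` share one core and differ only at the saturated chain carbon bound to an amine nitrogen and a carbonyl carbon. In an ADME assay on a cell-free system (plasma, Homo sapiens) for metabolic stability, with Plasma (Rattus norvegicus) as the target, read by HPLC (a lower number here means that the compound disappears faster, a higher number that the compound lasts longer), compound 1 gives > 3 h, which is a limit of the assay. Compound 2 gives a limit as well, > 3 h. Compound 3 reaches a limit too, > 3 h. The step that the two limits leave unreadable from compound 2 to compound 1 follows the change (methyl in place of hydrogen on a saturated chain carbon bound to an amine nitrogen and a carbonyl carbon); with both ends at a limit its size is not readable, as the limit of > 3 h in this assay, at which 3 of the 3 values shown sit, shows. The same holds for a step that the two limits leave unreadable from compound 1 to compound 3 and a step that the two limits leave unreadable from compound 2 to compound 3.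

Compound 4 `CC[C@H](C)[C@@H](N)C(=O)N1CC(=O)N(CCCC(C)Nc2cc(OC)cc3cccnc23)C1(C)C` is not yet measured. Its core differs from that of compound 2 by isopropyl in place of hydrogen on a saturated chain carbon bound to an amine nitrogen and a carbonyl carbon. The change from compound 3 to compound 4 is methyl in place of hydrogen on a saturated chain carbon, three bonds along the chain from an amine nitrogen and a carbonyl carbon; it is the same kind of change as that from compound 2 to compound 1, but the place differs: there the carbon is bound to an amine nitrogen and a carbonyl carbon, here it is three bonds along the chain from them. The step that the limit leaves unreadable from compound 3 to compound 4 is expected to be small, resting on (the limit of > 3 h in this assay, at which 3 of the 3 values shown sit), where all three values sit. Compound 4 is estimated at 4 h in this assay, most likely again as a limit.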

Compound 4, half-life: > 3 h
Compound 4 was reported as a limit; the forecaster's own chance of this, stated with the estimate: 80%; the middle value does not contradict the limit.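

In this assay compound 4 gives > 3 h, again a limit. No new step can be read from compound 4 to compound 1, compound 2 or compound 3: the limit of > 3 h in this assay, at which 4 of the 4 values shown sit.

The compounds shown leave open how long each lasts beyond this limit, and whether the changes at the saturated chain carbon alter half-life at all.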